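Swapping the aryl amide for a pyrrolidine ring

The source may report more compounds than this note shows. Statements on the series, on what has been measured and on what is new or still open speak of the compounds shown alone.

Two compounds share a core in which a sulfonamide-bearing piperidine is capped by an amide, and both were tested in an assay on U2OS cells for inhibition of secreted frizzled-related protein 1 (Homo sapiens), read by a luciferase reporter, with a stated time of 18 h; on this read-out higher numbers stand for an effect only at larger amounts of compound and lower numbers for an effect already at smaller amounts. Compound 1 `O=C(c1ccccc1)N1CCC(NS(=O)(=O)c2cc(S(=O)(=O)c3ccccc3)ccc2C(F)(F)F)CC1` carries a phenyl on the carbonyl carbon and gives 250 nM. Compound 2 `CN(C)c1ccc(C(=O)N2CCC(NS(=O)(=O)c3cc(S(=O)(=O)c4ccccc4)ccc3C(F)(F)F)CC2)cn1`, with a 6-(dimethylamino)pyridin-3-yl in that place, gives 70 nM. For the measured compounds named here, that change is a 3.6-fold lower number from compound 1 to compound 2 (0.55 log units; beyond the scatter), so compound 2 holds the lowest of the two numbers so far, and compound 1 is its only neighbour.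

Compound 3 `O=C([C@H]1CCNC1)N1CCC(NS(=O)(=O)c2cc(S(=O)(=O)c3ccccc3)ccc2C(F)(F)F)CC1` is the next step from compound 2: pyrrolidin-3-yl in place of 6-(dimethylamino)pyridin-3-yl on a carbonyl carbon. Going by the values given here, no measured pair covers an aromatic-to-saturated ring swap here; the single step from compound 1 to compound 2 only shows that what sits on the carbonyl carbon can move the number beyond the scatter. With the group that helped in compound 2 removed and nothing like the new ring measured, the number for compound 3 is expected to rise, roughly back toward compound 1, by a 4.3-fold higher number from compound 2 to compound 3 (0.63 log units; beyond the scatter). Compound 3 is therefore estimated at 300 nM, within 70 nM to 1500 nM.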

Compound 3, half-maximal effective concentration: 700 nM
Beside the measured number, compound 3's estimate is 2.3-fold (0.37 log units) below it; the range from low to high includes it.
By their numbers in this assay, from the lowest: compound 2; then compound 1; then compound 3.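

The saturated pyrrolidin-3-yl gives the largest step seen so far on this carbonyl carbon, a 10-fold higher number from compound 2 to compound 3 (1.00 log units; beyond the scatter), compared with a 3.6-fold lower number from compound 1 to compound 2 (0.55 log units; beyond the scatter). It also falls short of the plain phenyl, a 2.8-fold higher number from compound 1 to compound 3 (0.45 log units; beyond the scatter), so what matters here is more than simply removing the 6-(dimethylamino)pyridin-3-yl: among these three groups, the order from lowest to highest number is 6-(dimethylamino)pyridin-3-yl, phenyl, pyrrolidin-3-yl, with each step beyond the scatter. This one change replaces a six-membered aromatic ring with a smaller non-aromatic ring and also brings in a hydrogen-bond donor and a defined stereocentre, and no measurement at hand explains the rise or assigns it to any one of these differences.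

A cyclopentyl group would test whether the ring nitrogen matters apart from the loss of the aromatic ring, while the opposite stereoisomer of pyrrolidin-3-yl would test whether the defined stereocentre matters. A pyridin-3-yl without the dimethylamino group would show how much of the low number of compound 2 comes from the ring and how much from the amine.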